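The source may report more compounds than this note shows. Statements on the series, on what has been measured and on what is new or still open speak of the compounds shown alone.

Measured so far in a functional assay on SJ-G2 cells (Homo sapiens) for inhibition, read by MTT assay, with a stated time of 72 h; a higher number here means a weaker inhibitor of growth, a lower number a stronger inhibitor of growth:
compound 1 `N#C/C(=C\c1ccc[nH]1)C(=O)NCc1ccc(Cl)c(Cl)c1` — compound 1 gives > 50000 nM, a limit of the assay and not a number.
compound 2 `COc1ccc(CNC(=O)/C(C#N)=C/c2ccc(C)cc2)cc1` — compound 2 gives 39000 nM.

Compound 1 stands only at a limit in this assay; the one limit in the set is the limit of > 50000 nM in this assay, at which 1 of the 2 values shown sits. Compound 2 sits at a number not far from that limit. Compound 3 `COc1ccc(/C=C(\C#N)C(=O)NCc2ccc(Cl)c(Cl)c2)cc1` differs from compound 1 by 4-methoxyphenyl in place of 1H-pyrrol-2-yl on a double-bonded chain carbon bound to a double-bonded chain carbon. Among the measured compounds shown here, no step between two measured compounds is available, so the size of this change cannot be read from the data. Compound 2 also carries a six-membered carbon-only aromatic ring on a double-bonded chain carbon and sits near the limit, which points to a change within or near the scatter; the expected step is an at least 1.2-fold lower number from compound 1 to compound 3 (0.09 log units; that floor lies within the scatter). Compound 3 is estimated at 40000 nM, with a range from 15000 nM to 100000 nM, and a fair chance that this assay again reports only a limit.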

Compound 3, concentration for 50% growth inhibition: > 100000 nM
Compound 3: a limit, no number; the forecaster's own chance of this, stated with the estimate: 40%; middle value at least 2.5-fold (0.39 log units) away from the limit.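

Among the compounds shown here, compound 1 and compound 3 both stand only at limits in this assay, so no step between them can be read. The compounds shown leave open whether 4-methoxyphenyl in place of 1H-pyrrol-2-yl changes growth inhibition at all, and in which direction.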